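Shortening the side chain on a shared benzimidazole-free core

A few compounds are considered here, and "the series" means these few. Any claim that something is new, unique, unknown or untested is made for them only; others in the source may bear on it.

Measured compounds:
- compound 1, `CN1CCN(c2nc3ccccc3n2CCOc2ccccc2)CC1`: 6.9 nM
- compound 2, `CCCSCn1c(N2CCN(C)CC2)nc2ccccc21`: 68 nM

In a functional assay on ileum for inhibition of histamine H1 receptor (Cavia porcellus) (on this read-out lower numbers stand for stronger inhibition and higher numbers for weaker inhibition), compound 1 gives 6.9 nM, and compound 2 gives 68 nM. Going by the values given here, compound 2 thus stands with the higher of the two numbers, and its only neighbour is compound 1; the step of a 9.9-fold higher number from compound 1 to compound 2 (0.99 log units; beyond the scatter) lies beyond the scatter.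

Compound 3, `CCCn1c(N2CCN(C)CC2)nc2ccccc21`, has not yet been measured. It differs from compound 2 as follows: ethyl in place of propylsulfanyl on a saturated chain carbon bound to an aromatic nitrogen.

Among the compounds with values here, the one step on record that bears on this place is a 9.9-fold higher number from compound 1 to compound 2 (0.99 log units; beyond the scatter), where the group on the saturated chain carbon bound to the aromatic nitrogen was already exchanged once and the number rose. The present change trims that group again, to a shorter chain. Nothing measured shows how a plain ethyl behaves at this place, so the direction is uncertain; the prior step suggests that the number may rise somewhat further, but a move within the scatter is also possible. The step from compound 2 to compound 3 is therefore expected to be a 2.2-fold higher number from compound 2 to compound 3 (0.34 log units; beyond the scatter), and compound 3 is estimated to give 150 nM in this assay, within a range from 40 nM to 600 nM.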

Compound 3, half-maximal inhibitory concentration: 380 nM
Compound 3: the middle estimate sits 2.5-fold (0.40 log units) below what was measured; the range from low to high includes it.
By their numbers in this assay, from the lowest: compound 1; then compound 2; then compound 3.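

The exchange of propylsulfanyl for ethyl on a saturated chain carbon bound to an aromatic nitrogen gives, in this assay, a 5.6-fold higher number from compound 2 to compound 3 (0.75 log units; beyond the scatter), so the number keeps rising after the phenoxy ring has already gone, and a group without a ring can still make a difference beyond the scatter. Measured against the start of the series, the exchange of phenoxy for methyl gives a 55-fold higher number from compound 1 to compound 3 (1.74 log units; beyond the scatter), which makes compound 3 the compound with the highest number of the three, and the order runs from phenoxymethyl through propylsulfanyl to ethyl at this place, with none of the three compounds going against it. Nothing at hand accounts for this rise at this place.

The compounds shown leave open whether the number follows the length of the chain or the loss of the sulfur, since the last exchange removes both at once. A pentyl chain, or an ether oxygen standing where the sulfur stands, would tell these two readings apart, and a terminal amine on the chain would show whether anything other than a plain chain is tolerated here.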